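Thioacetate series: ester to free acid at compound 4

The source may report more compounds than this note shows. Statements on the series, on what has been measured and on what is new or still open speak of the compounds shown alone.

Working notes. Compound 1 `CCOC(=O)C(CCCCCN)CSC(C)=O` is the ethyl ester bearing a thioacetate on the chain; in an assay on isolated protein for inhibition of carboxypeptidase B2 (Homo sapiens), read by spectrophotometry, with stated times of 10 min and 30 min (on this read-out higher numbers stand for weaker inhibition and lower numbers for stronger inhibition), compound 1 gives 310000 nM, the highest of the two numbers available, with compound 3 `CCOC(=O)C(CCCCCN)C[Se]C(=O)CC` nearest at 1400 nM. Compound 2 `CCOC(=O)C(C[Se]C(=O)CC)Cc1cnc(N)c(Cl)c1` reaches only a limit in this assay, > 3800000 nM. That limit, (the limit of > 3800000 nM in this assay, at which 1 of the 3 values shown sits), is where one of the three reported values sits. Among the compounds with values here, the only measured step with one change is a 220-fold lower number from compound 1 to compound 3 (2.35 log units; beyond the scatter), a swap at the chain carbon two bonds from the carbonyl, not at the ester.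

Compound 4 `CC(=O)SCC(CCCCCN)C(=O)O` differs from compound 1 by hydrogen in place of ethyl on an oxygen next to a carbonyl group, that is ethoxycarbonyl to carboxy. Within the data shown here, no measured step touches this position, so the step from compound 1 to compound 3 gives no direct guide. A lower number in this assay is nevertheless expected for compound 4, of size a 10-fold lower number from compound 1 to compound 4 (1.01 log units; beyond the scatter), with wide uncertainty. The estimate for compound 4 in this assay is 30000 nM, expected between 4000 nM and 250000 nM.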

Compound 4, half-maximal inhibitory concentration: 3800 nM
For compound 4 the middle estimate is 7.9-fold (0.90 log units) above the measured one; the measured number lies below the stated range.
By their numbers in this assay, from the lowest: compound 3; then compound 4; then compound 1. At a limit, above all of these: compound 2.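

Ethoxycarbonyl to carboxy gives the first measured change at the ester itself: in this assay, the step is an 82-fold lower number from compound 1 to compound 4 (1.91 log units; beyond the scatter). The earlier step from compound 1 changed only the chain group, so the series now has a large step at the ester as well, with the thioacetate and the aminopentyl chain left unchanged. No measured result given here accounts for the size of this step.

Compounds 3 and 4 differ in more than one place, so they say nothing about whether hydrogen in place of ethyl would give a similar step on the core of compound 3. Also open, going by these compounds, is how a primary amide or a methyl ester would compare with the carboxy group of compound 4 on the same core.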